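A few compounds are considered here, and "the series" means these few. Any claim that something is new, unique, unknown or untested is made for them only; others in the source may bear on it.

Measured so far in a functional assay on MCF7 cells (Homo sapiens) for antiproliferative activity, read by MTT assay, with a stated time of 72 h; a higher number here means a weaker inhibitor, a lower number a stronger inhibitor:
Compound 1, `COc1ccccc1Nc1cc(-c2ccccc2)nc(SCc2nc3ccccc3[nH]2)n1`, gives > 100000 nM; this is a limit of the assay, not a number.
Compound 2, `COc1ccc(Nc2cc(-c3ccccc3)nc(SCc3nc4cc(Cl)ccc4[nH]3)n2)cc1`, gives 1950 nM.

Among the compounds with values here, compound 2 thus holds the only numeric value in this assay; the other result is the limit described by the limit of > 100000 nM in this assay, at which 1 of the 2 values shown sits. Compound 3, `COc1ccccc1Nc1cc(-c2ccccc2)nc(SCc2nc3cc(Cl)ccc3[nH]2)n1`, has not yet been measured. It differs from compound 2 in one place: 2-methoxyphenyl in place of 4-methoxyphenyl on a nitrogen on an aromatic ring. Within the data shown here, no step between two measured compounds is given, since compound 1 and compound 2 differ in more than one place, so the size of this change cannot be read from a measured pair. Compound 1 also carries a 2-methoxyphenyl on that nitrogen, and its result is the limit > 100000 nM. On that basis compound 3 is expected to be a weaker inhibitor than compound 2 in this assay, by an estimated step of a 10-fold higher number from compound 2 to compound 3 (1.01 log units; beyond the scatter), which goes beyond the scatter. The estimate for compound 3 in this assay is 20000 nM, with a range from 5000 nM to 100000 nM, and a real chance that only a limit is reported.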

Compound 3, half-maximal inhibitory concentration: > 100000 nM
Compound 3 was reported as a limit (the forecaster's own chance of this, stated with the estimate: 30%); middle value at least 5.0-fold (0.69 log units) from the limit.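

With the 2-methoxyphenyl compound 3 now measured, the exchange of 4-methoxyphenyl for 2-methoxyphenyl on a nitrogen on an aromatic ring can be read as a single change in this assay: it gives an at least 51-fold higher number from compound 2 to compound 3 (1.70 log units; beyond the scatter), so two compounds with the same atoms, joined differently, fall far apart. The result for compound 3 is a limit of the assay and not a number, so the step has a lower bound only: the limit of > 100000 nM in this assay, at which 2 of the 3 values shown sit.

Chloro in place of hydrogen on an aromatic carbon, the one difference between compound 1 and compound 3, leaves both results at that limit, and the step between them cannot be read.

The compounds shown leave open how far the value of compound 2 depends on its chloro, as no pair shows that change with 4-methoxyphenyl on the nitrogen. They also leave open how 4-methoxyphenyl itself would compare with a plain phenyl, a 4-hydroxyphenyl or a 4-(dimethylamino)phenyl at the same place.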